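The source may hold more compounds than are shown below. What is called first, only, known or untested is meant among the compounds shown, and "the series" means these compounds.

Measured so far in an ADME assay on BHK cells (Mesocricetus auratus) for cytotoxicity, read by MTT assay, with a stated time of 96 h (a higher number here means that more compound is tolerated, a lower number that less compound is tolerated), for this series:
- compound 1 `FC(F)(F)c1cccc(NC(=S)Nc2ccc(Cl)cc2)c1` gives 10000 nM as a number
- compound 2 `C=C(C)CNC(=S)Nc1cccc(C(F)(F)F)c1` gives > 100000 nM as a limit

Compound 2 stands with > 100000 nM as a limit of the assay and not as a number. Compound 3 `CSCCCNC(=S)Nc1cccc(C(F)(F)F)c1` alters the chain of compound 2 as follows: 2-(methylsulfanyl)ethyl in place of 1-methylethenyl on a saturated chain carbon bound to an amide-type nitrogen and the group on the amide-type nitrogen still carries no ring. Among the compounds with values here, only one measured step bears on this, and only loosely: an at least 10-fold higher number from compound 1 to compound 2 (1.00 log units; beyond the scatter) with the change made on the same type of nitrogen. Compound 3 stays on the ring-free side of that step, so no step beyond the scatter is expected in this assay and any shift would be towards a lower number. The expected step is a number no higher from compound 2 to compound 3 (the limit leaves the size open) for this pair. For compound 3 the estimate is 100000 nM with an expected range from 30000 nM to 150000 nM overall.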

Compound 3, half-maximal cytotoxic concentration: > 100000 nM
Compound 3: no number, only a limit; the forecaster's own chance of this, stated with the estimate: 60%; the middle value lies on the limit itself.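

In this assay compound 3 gives > 100000 nM, a limit of the assay and not a number. Replacing 4-chlorophenyl by 3-(methylsulfanyl)propyl on the amide-type nitrogen gives an at least 10-fold higher number from compound 1 to compound 3 (1.00 log units; beyond the scatter), so a second ring-free chain, this one with a sulfur atom and no double bond outside aromatic rings, repeats what 2-methylprop-2-en-1-yl showed. The step between the two ring-free chains cannot be read, and the two cannot be ordered: the limit of > 100000 nM in this assay, at which 2 of the 3 values shown sit.

Open, as far as these compounds go, is whether any ring-free chain on this nitrogen, for instance one ending in an amine or a carboxylic acid, gives a number in this assay rather than a limit. Also open, from the compounds shown here alone, is whether the lower tolerated concentration goes with the ring or with its chlorine, which a plain phenyl or a cyclohexyl group on the same nitrogen would separate.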